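The source may report more compounds than this note shows. Statements on the series, on what has been measured and on what is new or still open speak of the compounds shown alone.

In a functional assay on cells (Panel NCI-60 (60 carcinoma cell lines), Homo sapiens) for inhibition, read by colorimetric assay, with a stated time of 3 days (a lower number here means a stronger inhibitor of growth, a higher number a weaker inhibitor of growth), compound 1 (`O=C(CCCCCCNC(=O)C(O)(O)C(F)(F)F)Nc1ncc(-c2ccc(Br)cc2)s1`) gives 11400 nM.

Compound 2 (`COc1ccc(NC(=O)CCCCCCNC(=O)C(O)(O)C(F)(F)F)cc1`) has the entry "not determined" (no result reported).

Compound 3 (`O=C(CCCCCCNC(=O)C(O)(O)C(F)(F)F)Nc1ccc(Br)cc1`) gives 20900 nM.

Compound 3 at 20900 nM lies within the usual scatter of compound 1 at 11400 nM and the two cannot be ranked. Compound 2 adds no number to the comparison, so the picture in this assay rests on these two values alone.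

The next analogue is compound 4 (`O=C(CCCCCCNC(=O)C(O)(O)C(F)(F)F)Nc1ccc(-c2ccccc2)cc1`), which carries phenyl in place of bromo on an aromatic carbon, para to a large group (phenyl in place of bromo on an aromatic carbon). Within the data shown here, no measured pair differs at one place only, so this change has no direct precedent. The two available values sit close together and give no sign of a large move in either direction. The working expectation is a small shift toward a lower number or none beyond the scatter. The estimated change is a 1.4-fold lower number from compound 3 to compound 4 (0.14 log units; within the scatter) and it is expected to stay within the scatter. For compound 4 the expected value is 15000 nM (estimated range 6000 nM to 40000 nM).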

Compound 4, concentration for total growth inhibition: 15100 nM
Compound 4: the middle estimate sits 1.0-fold (0.00 log units) below what was measured; the measured number falls inside the stated range.
By their numbers in this assay, from the lowest: compounds 1, 4 and 3 (each within the scatter of the next).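

In this assay, among these compounds, phenyl in place of bromo on an aromatic carbon, para to a large group, gives a 1.4-fold lower number from compound 3 to compound 4 (0.14 log units; within the scatter), and this is the first step in which the compounds differ in one place only. At this position, the change from a single bromine atom to a substituent of 6 heavy atoms, with one six-membered aromatic ring of carbon only, leaves the number within the scatter, so the two compounds cannot be ranked and added size at this place shows no measurable cost or gain in this read-out. No measurement at hand bears on the reason for this outcome.

On these data alone, whether a quite different group at this position, such as an amine or a carboxylic acid, would move the number beyond the scatter remains open. Among the compounds shown here, also open is how the number responds to a change elsewhere in the shared core, such as a longer chain or a replacement of the trifluoromethyl group, since the single step available speaks only to bromo and phenyl at one place.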